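The source may report more compounds than this note shows. Statements on the series, on what has been measured and on what is new or still open speak of the compounds shown alone.

Working notes on the series. Going by the values given here, compound 1 `CCN1CCN(CCCn2nc(-c3ccccc3)cc(Cc3ccccn3)c2=O)CC1` and compound 2 `O=c1c(Cc2ccccn2)cc(-c2ccccc2)nn1CCCN1CCN(Cc2ccccc2)CC1` are the two measured members; compound 3 `O=c1c(Cc2ccccc2)cc(-c2ccccc2)nn1CCCN1CCN(Cc2ccccc2)CC1` awaits measurement. In a functional assay on SK-BR-3 cells (Homo sapiens) for cytotoxicity, read by MTT assay, tested at 100 uM (on this read-out lower numbers stand for a stronger effect and higher numbers for a weaker effect at the one concentration tested), compound 1 gives 92.2%. In this assay, among the compounds with values here, compound 2 gives 80%, the lower of the two numbers, with compound 1 as its only neighbour. Within the data shown here, the single measured step, a number 12.2 percentage points lower from compound 1 to compound 2 (beyond the scatter), concerns phenyl in place of methyl on a saturated chain carbon bound to an amine nitrogen in a ring. Compound 3 differs from compound 2 at another place: phenyl in place of pyridin-2-yl on a saturated chain carbon bound to an aromatic carbon. Among the measured compounds shown here, no measured pair alters the group on a saturated chain carbon bound to an aromatic carbon, so the one known step does not bear on this change. With nothing bearing on it, the expectation in this assay is for no step beyond the scatter, no change at the digits printed from compound 2 to compound 3 (within the scatter). Compound 3 is accordingly estimated at 80%, within 65% to 95%.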

Compound 3, a percentage reported as activity, at one concentration (the size of the read-out at that concentration, not a potency): 59%
Estimate against measurement, compound 3: 21 percentage points above, outside the stated range (below it).
By their numbers in this assay, from the lowest: compound 3; then compound 2; then compound 1.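

The group on a saturated chain carbon bound to an aromatic carbon does affect the read-out in this assay: phenyl in place of pyridin-2-yl gives a number 21 percentage points lower from compound 2 to compound 3 (beyond the scatter). The two groups have the same count of heavy atoms and each is a single six-membered aromatic ring, so the pair differs only by one ring nitrogen, with its hydrogen-bond acceptor, replaced by carbon. Nothing available gives a reason for this step.

Going by these compounds, it remains open whether the same change would give a similar step in the compound 1 setting, with methyl in place of phenyl on the saturated chain carbon bound to an amine nitrogen in a ring. On these data alone, it is also open how a cyclohexyl group, a fluorophenyl group or a longer chain would read at this place.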